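The source may hold more compounds than are shown below. What is called first, only, known or untested is meant among the compounds shown, and "the series" means these compounds.

Measured in a functional assay on the whole organism with Mus musculus as the target, with a stated time of 30 min; a higher number here means that more compound is needed for the effect, a lower number that less compound is needed:
compound 1 `CCC(=O)NCC1CCCN(S(=O)(=O)c2ccc(F)cc2)C1` gives 10 mg/kg
compound 2 `CCC(=O)N1CCCC(NC(=O)c2ccccc2)C1` gives 1 mg/kg

Compound 1 stands at the higher of these two numbers; compound 2 gives a lower number, and that gap lies beyond the usual scatter. Compound 3 `CC(C)S(=O)(=O)NC1CCCN(S(=O)(=O)c2ccc(F)cc2)C1` has not yet been measured. It differs from compound 1 in one place: (isopropylsulfonyl)amino in place of (propanoylamino)methyl on a saturated ring carbon. Going by the values given here, no measured pair shows a change of this kind, so nothing here points to a direction. The step from compound 1 to compound 3 is expected to be small, none beyond the scatter: no change at the digits printed from compound 1 to compound 3 (within the scatter). Compound 3 is thus expected to give about 10 mg/kg, within 3 mg/kg to 30 mg/kg.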

Compound 3, minimum effective dose: 1 mg/kg
Compound 3: middle estimate off by 10-fold (1.00 log units), on the high side; the measured number lies below the stated range.
By their numbers in this assay, from the lowest: compounds 2 and 3 (each within the scatter of the next); then compound 1.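

In this assay, the group on this saturated ring carbon clearly matters: with the rest of compound 1 kept, placing (isopropylsulfonyl)amino where (propanoylamino)methyl stood gives a 10-fold lower number from compound 1 to compound 3 (1.00 log units; beyond the scatter). Going by these compounds alone, this is the first measured pair to isolate a change at this position, so the position can be seen to respond to substitution.

Whether the isopropyl or the sulfonyl part accounts for the step stays open, as does the outcome with an amine, a carboxylic acid or a longer chain at this carbon. Nothing available explains the size of this step.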